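The source may hold more compounds than are shown below. What is called first, only, known or untested is meant among the compounds shown, and "the series" means these compounds.

Measured in a functional assay on T47D cells (Homo sapiens) for cytotoxicity, read by MTT assay; a lower number here means a stronger inhibitor, a higher number a weaker inhibitor:
- compound 1 `O=C(/C=C/c1ccc(N2CCCC2)cc1)c1ccc(O)cc1`: 1370 nM
- compound 2 `O=C(/C=C/c1ccc(N2CCCC2)cc1)c1ccc(O)cc1O`: 6990 nM
- compound 3 `O=C(/C=C/c1ccc(F)cc1)c1ccc(O)cc1`: 13800 nM

Of these three, compound 1 stands lowest and is thus the strongest inhibitor in this assay. Compound 4 `O=C(/C=C/c1ccc(N2CCCC2)cc1)c1ccc([N+](=O)[O-])cc1` has not yet been measured. It differs from compound 1 by one change, nitro in place of hydroxy on an aromatic carbon.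

For the measured compounds named here, no measured step replaces that hydroxy, so the evidence is indirect. The closest is a 5.1-fold higher number from compound 1 to compound 2 (0.71 log units; beyond the scatter), a change of hydroxy in place of hydrogen on an aromatic carbon. The other is a 10-fold higher number from compound 1 to compound 3 (1.00 log units; beyond the scatter), which removes the pyrrolidin-1-yl that compound 4 keeps, so it bears less directly. Both changes lead to higher numbers, but two steps establish no rule, and neither involves nitro. A modest rise is therefore expected, with wide uncertainty, and the estimated step is a 2.9-fold higher number from compound 1 to compound 4 (0.47 log units; beyond the scatter). For compound 4 the expected value is 4000 nM, with an estimated range from 1000 nM to 16000 nM.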

Compound 4, half-maximal inhibitory concentration: 21300 nM
The estimate for compound 4 lay 5.3-fold (0.73 log units) below the measured number, and the stated range ends below it.
By their numbers in this assay, from the lowest: compound 1; then compounds 2, 3 and 4 (each within the scatter of the next, the first and the last beyond it).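

In this assay, exchanging the hydroxy for nitro on this aromatic carbon, para to a large group, gives a 16-fold higher number from compound 1 to compound 4 (1.19 log units; beyond the scatter), with the pyrrolidin-1-yl and the rest of the core of compound 1 unchanged. For the compounds shown here, compounds 1, 2 and 3 all keep this hydroxy, so compound 4 is the first to show that the number responds to what sits at this place, and that nitro, which has no hydrogen-bond donor, is no match for hydroxy here. Nothing measured here explains the rise.

The compounds shown leave open whether the rise follows the loss of the hydroxy or the arrival of the nitro, as none carries a plain hydrogen at this place. They also do not tell how an amine, a methoxy group or a carboxylic acid would read there in this assay.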